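Swapping the nitrogen substituent of a flavone-like core

The source may hold more compounds than are shown below. What is called first, only, known or untested is meant among the compounds shown, and "the series" means these compounds.

Compound 2 `C=CCNC(=O)n1c(-c2ccc(OC)cc2)cc(=O)c2c(OC)cc(OC)cc21` carries an allylcarbamoyl group on an aromatic nitrogen of the shared core. In an ADME assay on BJ cells (Homo sapiens) for antiproliferative activity, with a stated time of 72 h (on this read-out higher numbers stand for an effect only at larger amounts of compound and lower numbers for an effect already at smaller amounts), compound 2 gives 74000 nM. Among the compounds with values here, its only neighbour is compound 1 `COc1ccc(-c2cc(=O)c3c(OC)cc(OC)cc3n2C)cc1`, which has a methyl on that aromatic nitrogen; in this assay compound 1 gives 68000 nM. The step of a 1.1-fold higher number from compound 1 to compound 2 (0.04 log units; within the scatter) shows that exchanging the group on the aromatic nitrogen left the read-out essentially unchanged, and compound 2 holds the higher of the two numbers only by a margin that means nothing.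

Compound 3 `COc1ccc(-c2cc(=O)c3c(OC)cc(OC)cc3n2S(=O)(=O)c2ccc(C=O)cc2)cc1` differs from compound 2 at the same aromatic nitrogen: (4-formylphenyl)sulfonyl in place of allylcarbamoyl on an aromatic nitrogen. Within the data shown here, the one step that speaks to this place, from compound 1 to compound 2, was within the scatter, so the expectation for this assay is no step beyond the scatter, in either direction, while the larger entering group leaves the uncertainty wide. The estimated step from compound 2 to compound 3 is a 1.1-fold lower number from compound 2 to compound 3 (0.02 log units; within the scatter). Compound 3 is therefore expected to give about 70000 nM in this assay, within a range from 20000 nM to 200000 nM.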

Compound 3, half-maximal effective concentration: > 34400 nM
Compound 3 was reported as a limit (the forecaster's own chance of this, stated with the estimate: 20%); the middle value does not contradict the limit.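

Compound 3 is reported in this assay only as a limit, > 34400 nM. Its steps from compound 1 and from compound 2 therefore cannot be read. The compounds shown leave open whether (4-formylphenyl)sulfonyl on the aromatic nitrogen changes the read-out compared with methyl or allylcarbamoyl, or leaves it essentially the same.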